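The source may hold more compounds than are shown below. What is called first, only, known or untested is meant among the compounds shown, and "the series" means these compounds.

Measured so far:
Compound 1, `COc1cc(/C=C/c2ccc(NC(=O)/C=C/c3cc(OC)c(OC)c(OC)c3)cc2)cc(OC)c1`: 2140 nM
Compound 2, `COc1cc(/C=C/c2ccc(NC(=O)/C=C/c3ccc(F)cc3)cc2)cc(OC)c1`: 9390 nM

Both compounds were tested in a functional assay on MDA-MB-231 cells (Homo sapiens) for inhibition, read by MTT assay, with a stated time of 48 h; a lower number here means a stronger inhibitor, a higher number a weaker inhibitor. Compound 1 gives 2140 nM, while compound 2 gives 9390 nM, the higher of the two numbers; the gap between them lies beyond the scatter of the method, so compound 2 is the weaker inhibitor of this pair. Within the data shown here, no step between the two is set out here, since they differ in more than one place.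

Compound 3, `COc1cc(/C=C/c2ccc(NC(=O)/C=C/c3ccc(Br)cc3)cc2)cc(OC)c1`, has not yet been measured. It differs from compound 2 by bromo in place of fluoro on an aromatic carbon, on an aromatic carbon of a six-membered aromatic ring of carbon only, para to a large group. Among the measured compounds shown here, nothing among the measured compounds shows what such an exchange does in this assay, so the expectation rests on the change being a single halogen for another at the same place. The step from compound 2 to compound 3 is expected to be small, probably within the scatter, with a slight lean toward a lower number, estimated as a 1.3-fold lower number from compound 2 to compound 3 (0.13 log units; within the scatter). Compound 3 is thus expected to give about 7000 nM, within a range from 2500 nM to 20000 nM.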

Compound 3, half-maximal inhibitory concentration: 6160 nM
Compound 3: the middle estimate sits 1.1-fold (0.06 log units) above what was measured; measured number inside the range.
By their numbers in this assay, from the lowest: compound 1; then compounds 3 and 2 (each within the scatter of the next).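

In this assay, the step from fluoro to bromo on this aromatic carbon, para to a large group, comes to a 1.5-fold lower number from compound 2 to compound 3 (0.18 log units; within the scatter) and is the only change in a single place that can be read among these compounds. It shows that this position accepts either halogen without a difference the assay can separate, so compound 2 and compound 3 stand together on the evidence here, and the exchange of one halogen for the other, with no change in ring, charge or count of hydrogen-bond donors and acceptors, gives no measurable gain or loss. No measurement at hand explains this result or ties it to any property of the two halogens.

Going by these compounds, whether the same position would stay as undemanding with a group of another kind, such as an amine, a carboxylic acid, a nitrile or a methoxy group, remains open, since only two halogens have been seen there. Compound 1 differs from compound 2 and compound 3 in more than one place, so what the methoxy groups on its ring contribute, taken one at a time, also cannot be read.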